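Fluorine Position on the Amino-Linked Ring of Compound 1

This account rests on a few compounds, and the source may have more. Where it says the series, first, only, none or still open, it means among the compounds named here.

Compound 1 `COc1ccn2c(Nc3ccccc3F)c(-c3ccccn3)nc2c1`: 5750 nM in an ADME assay on THP-1 cells (Homo sapiens) for cytotoxicity; a higher number here means that more compound is tolerated, a lower number that less compound is tolerated.
Compound 2 `c1cncc(-c2nc3ccccn3c2NC2CCCC2)c1`: > 50000 nM in this assay, a limit of the assay.
Compound 3 `COc1ccc(-c2nc3ccccn3c2NC2CCCC2)c(F)c1`: > 50000 nM in this assay, a limit of the assay.

Of the compounds shown here, three have been measured in this assay. Compound 1 is the only one of them for which a number, rather than a limit, is reported; where it stands is set against (the limit of > 50000 nM in this assay, at which 2 of the 3 values shown sit). Compound 2 sits at that limit. Compound 3 sits at that limit as well.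

Compound 4 `COc1ccn2c(Nc3ccc(F)cc3)c(-c3ccccn3)nc2c1` has not yet been measured. It differs from compound 1 by 4-fluorophenyl in place of 2-fluorophenyl on a nitrogen on an aromatic ring; the two compounds contain the same atoms, joined differently. No two measured compounds differ in a single place, so no measured step is available to guide the expectation, and no cause can be given for any difference that might appear.

For a shift of the fluorine within the same ring, with no change in the rest of the structure, no step beyond the usual scatter of this assay is expected. Compound 4 is therefore expected to give 6000 nM in this assay, within a range from 2500 nM to 20000 nM. The expected step of a 1.0-fold higher number from compound 1 to compound 4 (0.02 log units; within the scatter) amounts to no change beyond the scatter.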

Compound 4, half-maximal cytotoxic concentration: 4560 nM
The estimate for compound 4 lay 1.3-fold (0.12 log units) above the measured number; the range from low to high includes it.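

In this assay, for the compounds shown here, the change from (2-fluorophenyl)amino to (4-fluorophenyl)amino gives the first step in this set that can be read between two measured compounds: a 1.3-fold lower number from compound 1 to compound 4 (0.10 log units; within the scatter). Going by these compounds alone, the fluorine can therefore occupy either of these two places on the amino-linked ring without a change that can be told from the scatter, and compound 1 is no longer the only compound with a number rather than a limit. Nothing measured here bears on why the two isomers fall so close together, and this one step gives no cause for the result.

The compounds shown leave open how 3-fluorophenyl, an unsubstituted phenyl, or a ring carrying a chlorine or a nitrile in place of the fluorine would compare with compound 1 and compound 4 in this assay. Within the data shown here, they also leave open what separates these two compounds from the limits reported for compound 2 and compound 3, as those two differ from them in more than one place and no steps to them can be read.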